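Swapping the pyrazole on the amide nitrogen

The source may hold more compounds than are shown below. What is called first, only, known or untested is meant among the compounds shown, and "the series" means these compounds.

Compound 1 `Cc1ccc(OCC(=O)N(Cc2cccs2)c2cnn(C)c2)cc1`: 63000 nM
Compound 2 `CCN(Cc1ccoc1)C(=O)COc1ccc(C)cc1`: 136 nM
Compound 3 `CCN(Cc1cccs1)C(=O)COc1ccc(Cl)cc1`: 39 nM

All three were measured in an assay on HEK293 cells for agonist activity at transient receptor potential cation channel subfamily M member 8 (Homo sapiens), read by fluorescence and calcium flux, with a stated time of 15 min; a higher number here means that more compound is needed for the effect, a lower number that less compound is needed. Compound 1 has the highest number of the three, well beyond the scatter from compound 2 and further still from compound 3, both of which carry an ethyl group rather than a pyrazole on the amide nitrogen. Compound 4 `Cc1ccc(OCC(=O)N(Cc2cccs2)c2c(C)n[nH]c2C)cc1` has not yet been measured. It differs from compound 1 in one place: 3,5-dimethyl-1H-pyrazol-4-yl in place of 1-methyl-1H-pyrazol-4-yl on an amide-type nitrogen. Among the measured compounds shown here, no pair of measured compounds shows this kind of change, so the direction is uncertain and the expected step is small, likely within the scatter. For compound 4 the expected value in this assay is 40000 nM, with a range from 10000 nM to 150000 nM. The step this estimate means is a 1.6-fold lower number from compound 1 to compound 4 (0.20 log units; within the scatter).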

Compound 4, half-maximal effective concentration: 0.3 nM
Estimate against measurement, compound 4: 130000-fold (5.12 log units) above, and the stated range ends above it.
By their numbers in this assay, from the lowest: compound 4; then compound 3; then compound 2; then compound 1.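

This place on the amide-type nitrogen is far from indifferent: in this assay, exchanging 1-methyl-1H-pyrazol-4-yl for 3,5-dimethyl-1H-pyrazol-4-yl gives a 210000-fold lower number from compound 1 to compound 4 (5.32 log units; beyond the scatter). A pyrazole on this nitrogen therefore does not by itself bring a high number, since the pattern around the ring decides the outcome. No available evidence explains a step of this size.

Going by these compounds, the entering group differs in both its methyl groups and its hydrogen-bond donor, so which difference matters remains open. On these data alone, whether an unsubstituted 1H-pyrazol-4-yl or a carboxylic acid here would behave similarly is also open.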